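Sulfonyl aryl variation on a shared quinoline-like core

A few compounds are considered here, and "the series" means these few. Any claim that something is new, unique, unknown or untested is made for them only; others in the source may bear on it.

Measured so far:
- Compound 1 `Cc1ccc(S(=O)(=O)c2cnc3ccc(Cl)cc3c2N2CCC(C)CC2)cc1C`: 84%
- Compound 2 `CC1CCN(c2c(S(=O)(=O)c3ccccc3)cnc3ccc(Cl)cc23)CC1`: 59%
- Compound 3 `COc1cccc(S(=O)(=O)c2cnc3ccc(Cl)cc3c2N2CCC(C)CC2)c1`: 87%

In an assay on isolated protein for displacement of a labelled ligand from metabotropic glutamate receptor 5 (Homo sapiens), with a stated time of 60 min, tested at 1 uM (on this read-out lower numbers stand for less inhibition and higher numbers for more inhibition at the one concentration tested (going by the name of the read-out)), compound 3 gives 87%, the highest of the three numbers; compound 1 sits a number 3 percentage points higher from compound 1 to compound 3 (within the scatter), and compound 2 sits a number 28 percentage points higher from compound 2 to compound 3 (beyond the scatter). Compound 4 `Cc1ccc(S(=O)(=O)c2cnc3ccc(Cl)cc3c2N2CCC(C)CC2)cc1` is not yet measured. It differs from compound 3 in one place: 4-methylphenyl in place of 3-methoxyphenyl on a sulfonyl sulfur. Within the data shown here, two measured steps bear on this. Stripping the aryl to plain phenyl gave a number 25 percentage points lower from compound 1 to compound 2 (beyond the scatter), while adding a methoxy to phenyl gave a number 28 percentage points higher from compound 2 to compound 3 (beyond the scatter). A single methyl on the ring therefore lands between the bare phenyl and the more substituted aryls, so a modest drop from compound 3 is expected, a number 13 percentage points lower from compound 3 to compound 4 (beyond the scatter). Compound 4 is estimated at 74%, with a likely range from 60% to 88%.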

Compound 4, a percentage reported as inhibition, at one concentration (the size of the read-out at that concentration, not a potency): 95%
The estimate for compound 4 lay 21 percentage points below the measured number; the measured number lies above the stated range.
By their numbers in this assay, from the lowest: compound 2; then compounds 1, 3 and 4 (each within the scatter of the next, the first and the last beyond it).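

A single methyl on the phenyl ring is enough here (a number 36 percentage points higher from compound 2 to compound 4 (beyond the scatter)), and more substitution brings no gain: the 3,4-dimethylphenyl group of compound 1 does not match it (a number 11 percentage points higher from compound 1 to compound 4 (beyond the scatter)). The 4-methylphenyl and 3-methoxyphenyl groups cannot be told apart (a number 8 percentage points higher from compound 3 to compound 4 (within the scatter)), so two different groups on this aryl ring give similar numbers. Nothing available explains these differences.

Open, on these data alone, is how an amine, a carboxylic acid or a longer chain such as propyl would fare on this ring. Also open, as far as these compounds go, is whether the same aryl preferences hold with another group in place of the chlorine on the shared core.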